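Nitrochromene series: ester for fluoro on the alkyne-linked ring

This account rests on a few compounds, and the source may have more. Where it says the series, first, only, none or still open, it means among the compounds named here.

Of the compounds shown here, two have numbers so far. Compound 1 `CC1Oc2ccc(I)cc2C=C1[N+](=O)[O-]` gives 36800 nM in an assay on 1321N1 cells for antagonist activity at P2Y purinoceptor 6 (Homo sapiens), read by FLIPR and calcium flux; a higher number here means a weaker inhibitor, a lower number a stronger inhibitor. Compound 2 `O=[N+]([O-])C1=Cc2cc(C#Cc3ccc(F)cc3)ccc2OC1C(F)(F)F` gives 8860 nM in this assay and stands lowest of the two values; the nearest, compound 1, lies higher by a step beyond the usual scatter. The two compounds differ in more than one place, so nothing more is drawn from that gap than what the two values show.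

The next compound, compound 3 `COC(=O)c1ccc(C#Cc2ccc3c(c2)C=C([N+](=O)[O-])C(C(F)(F)F)O3)cc1`, is not yet measured in this assay. It differs from compound 2 in one place: methoxycarbonyl in place of fluoro on an aromatic carbon. The change sits on an aromatic carbon of a six-membered aromatic ring of carbon only, para to a large group.

Going by the values given here, no measured pair shows this kind of exchange, so there is no step to lean on. The step from compound 2 to compound 3 is expected to be small, a 1.3-fold lower number from compound 2 to compound 3 (0.10 log units; within the scatter), not clearly beyond the scatter in either direction. For compound 3 the estimate in this assay is 7000 nM, with a range from 2500 nM to 25000 nM.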

Compound 3, half-maximal inhibitory concentration: 3970 nM
For compound 3 the middle estimate is 1.8-fold (0.25 log units) above the measured one; the measured number falls inside the stated range.
By their numbers in this assay, from the lowest: compound 3; then compound 2; then compound 1.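

In this assay, methoxycarbonyl in place of fluoro gives a 2.2-fold lower number from compound 2 to compound 3 (0.35 log units; beyond the scatter), a modest step but the first single-place comparison available in the series. This aromatic carbon, para to a large group, therefore accepts a substituent of 4 heavy atoms in place of a single fluorine, with 2 hydrogen-bond acceptors entering, and the number falls rather than rises. No measurement shown here bears on the reason for this step, so the change in the number is recorded without an explanation.

The compounds shown leave open how a carboxylic acid, a primary amide or a nitrile would read on this same carbon, and therefore whether the step is particular to methoxycarbonyl or would also appear with other groups in place of fluoro. They also leave open whether the same exchange would give a similar step with a methyl group in place of the trifluoromethyl on the shared core, since a single pair cannot show how far this step carries over.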